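Methoxy for methyl on the fused aromatic ring

The compounds below may be only part of what the source reports. "The series", "measured", "known", "first", "only" and "open" are said of these compounds alone.

Three compounds sharing one core have been run in a functional assay on OVCAR-3 cells (Homo sapiens) for inhibition, read by CCK-8 assay, with a stated time of 72 h, tested at 20 uM; on this read-out higher numbers stand for more inhibition of growth at the one concentration tested and lower numbers for less inhibition of growth. Compound 1 `CCOC(=O)/C=C1/C(=O)Nc2ccccc21` gives 57.3%, compound 2 `CN1C(=O)/C(=C/C(=O)OC(C)(C)C)c2ccccc21` gives 57.1%, and compound 3 `Cc1ccc2c(c1)/C(=C\C(=O)OC(C)(C)C)C(=O)N2` gives 59.5%. Compound 3 carries the top number of the three, but its gaps to compound 1 and to compound 2 both lie within the usual scatter, so the three results read as one level with no separation between them.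

Compound 4 `COc1ccc2c(c1)/C(=C\C(=O)OC(C)(C)C)C(=O)N2` is the next member and has not yet been measured in this assay. It differs from compound 3 in one place: methoxy in place of methyl on an aromatic carbon. Among the compounds with values here, no measured pair in this set shares that change, so the only guide is the flat picture given by compound 1, compound 2 and compound 3.

In this assay the expected change is a number 1.5 percentage points lower from compound 3 to compound 4 (within the scatter), nothing beyond the scatter in either direction. Compound 4 is therefore estimated at 58%, with a likely range from 45% to 70%.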

Compound 4, percent growth inhibition at one concentration: 59%
Estimate against measurement, compound 4: 1 percentage points below; low and high end bracket the measured number.
By their numbers in this assay, from the lowest: compounds 2, 1, 4 and 3 (each within the scatter of the next).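

In this assay, methoxy in place of methyl on this aromatic carbon, meta to a fused ring and para to a fused ring, gives a number 0.5 percentage points lower from compound 3 to compound 4 (within the scatter). Within the data shown here, this is the first step between two compounds that differ in one place, and it stays within the scatter. At this position, then, the change from methyl to methoxy, which adds a heavy atom and a hydrogen-bond acceptor, leaves the growth inhibition read-out at the level already seen, and nothing measured in the series speaks to why.

As far as these compounds go, whether an amine, a carboxylic acid or a longer chain on this same carbon would move the number beyond the scatter remains open. Also open, from the compounds shown here alone, is whether compound 3 and compound 4 would stay level at concentrations other than the single one tested.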